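Hydroxymethyl to Carbamoylmethyl: What One Step Suggests

The compounds below may be only part of what the source reports. "The series", "measured", "known", "first", "only" and "open" are said of these compounds alone.

Measured so far:
Compound 1, `CN(C)C(=O)C1CCN(c2nc(-c3cc(F)c(Cl)cc3F)nc3c2CS(=O)(=O)C3)CC1`, gives 350 nM in a functional assay on HEK293 cells for agonist activity at Glucose-dependent insulinotropic receptor (Homo sapiens), read by reporter gene assay and cAMP accumulation, with a stated time of 6 h; a lower number here means that less compound is needed, a higher number that more compound is needed for the effect.
Compound 2, `O=S1(=O)Cc2nc(-c3cc(F)c(Cl)cc3F)nc(N3CCC(CO)CC3)c2C1`, gives 3.9 nM in this assay.

Within the data shown here, compound 2 stands lowest of the two numbers; its only neighbour is compound 1, and the step of a 90-fold lower number from compound 1 to compound 2 (1.95 log units; beyond the scatter) is large and beyond the scatter. Compound 3, `NC(=O)CC1CCN(c2nc(-c3cc(F)c(Cl)cc3F)nc3c2CS(=O)(=O)C3)CC1`, differs from compound 2 by carbamoyl in place of hydroxy on a saturated chain carbon bound to a saturated ring carbon. Among the measured compounds shown here, the single measured step bears on this change: a 90-fold lower number from compound 1 to compound 2 (1.95 log units; beyond the scatter) came from exchanging dimethylcarbamoyl for hydroxymethyl, so an amide giving way to an alcohol went with a much lower number. Compound 3 moves in the opposite sense, putting a carbamoyl back in, though as carbamoylmethyl rather than directly on the ring carbon. Compound 3 is therefore expected to give a higher number than compound 2, though by a smaller step. The expected step is a 6.4-fold higher number from compound 2 to compound 3 (0.81 log units; beyond the scatter). Compound 3 is estimated at 25 nM, within 5 nM to 120 nM.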

Compound 3, effective concentration (reported as EC, without a stated level of effect): 8.3 nM
The estimate for compound 3 lay 3.0-fold (0.48 log units) above the measured number, and the stated range covers the measured number.
By their numbers in this assay, from the lowest: compound 2; then compound 3; then compound 1.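

In this assay the exchange of hydroxy for carbamoyl on this chain carbon is only a 2.1-fold higher number from compound 2 to compound 3 (0.33 log units; beyond the scatter) and so costs far less than the first step suggested. An amide at this end of the molecule therefore does not by itself bring a number like that of compound 1, as a 42-fold lower number from compound 1 to compound 3 (1.62 log units; beyond the scatter) shows for carbamoylmethyl in place of dimethylcarbamoyl. No measurement here gives a reason for either step.

That last step changes two things at once, the methyl groups on the amide nitrogen and the extra chain carbon, and the compounds shown cannot separate them. Going by these compounds, it also remains open whether a carboxylic acid, an amine or a longer chain would keep the number as low as these two groups do.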